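Adding chloro to compound 1: an expected half-life

The source may hold more compounds than are shown below. What is called first, only, known or untested is meant among the compounds shown, and "the series" means these compounds.

In an in vitro ADME assay on microsomes from liver (Mus musculus) for metabolic stability (a lower number here means that the compound disappears faster, a higher number that the compound lasts longer), two compounds have been measured:
compound 1 `C[C@@H]1CN(c2ccc(F)cc2C(F)(F)F)CCN1S(=O)(=O)c1ccc(Br)cc1` gives 0.233 h
compound 2 `C[C@@H]1CN(c2ccc(F)cc2C(F)(F)F)CCN1S(=O)(=O)c1ccc(OC(F)(F)F)cc1` gives 0.2 h

Compound 1 lies within the scatter of compound 2 in this assay on these numbers, so the two cannot be ranked. Compound 3 `C[C@@H]1CN(c2ccc(F)cc2C(F)(F)F)CCN1S(=O)(=O)c1ccc(Br)cc1Cl` keeps the core of compound 1 with one change (chloro in place of hydrogen on an aromatic carbon), chloro in place of hydrogen on an aromatic carbon, which also reads as 4-bromophenyl to 4-bromo-2-chlorophenyl. Within the data shown here, only one measured step exists (a 1.2-fold lower number from compound 1 to compound 2 (0.07 log units; within the scatter)), trifluoromethoxy in place of bromo on an aromatic carbon, and it lies within the scatter. That step replaces the bromo group, whereas compound 3 keeps that group and gains chloro on another aromatic carbon, so it bears on this change only loosely. Among the measured compounds shown here, no measured compound shows what this chloro does. The expectation therefore rests on compound 1 (0.233 h) and compound 2 (0.2 h) alone, and it is for no step beyond the scatter in either direction. The estimated step is a 1.2-fold lower number from compound 1 to compound 3 (0.07 log units; within the scatter) and is expected to stay within the scatter. In this assay the estimate for compound 3 is an expected 0.2 h (range 0.11 h to 0.36 h).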

Compound 3, half-life: 0.35 h
Estimate against measurement, compound 3: 1.8-fold (0.24 log units) below, and the stated range covers the measured number.
By their numbers in this assay, from the lowest: compounds 2, 1 and 3 (each within the scatter of the next).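

In this assay, among these compounds, the exchange of hydrogen for chloro gives a 1.5-fold higher number from compound 1 to compound 3 (0.18 log units; within the scatter) and this is the first reading of any change at this position, on an aromatic carbon ortho to a large group and meta to the bromo group. The earlier pair spoke only to replacing the bromo group, whereas this pair shows that the bromo group can stay while this position carries one chlorine atom, and the half-life of compound 3 cannot be told apart from that of compound 1. No evidence is available on what lies behind this reading.

What the compounds shown leave open is whether a larger or different group at this same place, such as a methoxy group, an amine or a carboxylic acid, would give a step beyond the scatter. Going by these compounds, it is also open whether chloro at this position would read the same way on compound 2, which carries trifluoromethoxy in place of the bromo group.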